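Cyclopropyl ketone to methyl ester on the fused bicyclic amine core

The source may report more compounds than this note shows. Statements on the series, on what has been measured and on what is new or still open speak of the compounds shown alone.

Measured so far:
compound 1 `C[C@H]1C[C@@H]1C(=O)N1CC2CNCC2C1` — 43 nM
compound 2 `O=C(C1CC1)[C@H]1C[C@H]2CNC[C@H]2C1` — 0.5 nM

In an assay on SHEP1 cells for displacement of a labelled ligand from Neuronal acetylcholine receptor; alpha4/beta2 (Homo sapiens), read by scintillation counting, with a stated time of 2 h (a higher number here means a weaker inhibitor, a lower number a stronger inhibitor), compound 2 gives 0.5 nM, the lowest of the two numbers measured; compound 1, the nearest, gives 43 nM, and the gap between the two values is beyond the scatter. Compound 3 `COC(=O)[C@H]1C[C@H]2CNC[C@H]2C1` is the next member and has not yet been measured. It differs from compound 2 in one place: methoxy in place of cyclopropyl on a carbonyl carbon. Within the data shown here, no step between measured compounds matches this change, and compound 1 alters a different part of the molecule, so the direction of this change is not anchored by any measured pair. The expectation is a modest step towards a higher number, of size a 6.0-fold higher number from compound 2 to compound 3 (0.78 log units; beyond the scatter), though a result within the scatter of compound 2 cannot be excluded. For compound 3 the estimate in this assay is 3 nM, with a range from 0.5 nM to 20 nM.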

Compound 3, inhibition constant: 8 nM
Compound 3: the middle estimate sits 2.7-fold (0.43 log units) below what was measured, and the stated range covers the measured number.
By their numbers in this assay, from the lowest: compound 2; then compound 3; then compound 1.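

Methoxy in place of cyclopropyl on a carbonyl carbon gives a 16-fold higher number from compound 2 to compound 3 (1.20 log units; beyond the scatter) in this assay and so shows that this place in the series is sensitive to the group it carries, a large step beyond the scatter. The change removes a three-membered ring of carbon only and brings in an oxygen with one hydrogen-bond acceptor, and this single pair cannot separate those two differences. No measurement on hand explains the size of the step.

The compounds shown do not settle whether the loss of the ring or the arrival of the oxygen carries the step; an ethyl ketone and an amine-derived amide on the same carbonyl carbon would be informative comparisons. Compound 1 differs from both compounds in more than one place, so it gives no reading on this change.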